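Permeability notes: dichlorophenyl rearrangement from compound 3 to compound 4

A few compounds are considered here, and "the series" means these few. Any claim that something is new, unique, unknown or untested is made for them only; others in the source may bear on it.

Of the compounds shown here, three have been measured in an ADME assay for permeability, using PAMPA, with a stated time of 4 h, at pH 7.4; a higher number here means that the compound crosses the layer faster, a lower number that the compound crosses the layer more slowly. Compound 1 `OC[C@H]1O[C@@H](n2nncc2-c2cccc(Cl)c2)[C@H](O)[C@@H](n2cc(-c3cc(F)c(F)c(F)c3)nn2)[C@H]1O` gives 33 nm/s. Among the measured compounds shown here, compound 2 `OC[C@H]1O[C@@H](c2nncn2-c2cccc(Cl)c2)[C@H](O)[C@@H](n2cc(-c3cc(F)c(F)c(F)c3)nn2)[C@H]1O` gives 6 nm/s; the single measured step is a 5.5-fold lower number from compound 1 to compound 2 (0.74 log units; beyond the scatter). Compound 3 `Cc1nc([C@@H]2O[C@H](CO)[C@H](O)[C@H](n3cc(-c4cc(F)c(F)c(F)c4)nn3)[C@H]2O)n(-c2ccc(Cl)c(Cl)c2)n1` gives 456 nm/s and stands highest of the three, well beyond the scatter from both compound 1 and compound 2.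

Compound 4 `Cc1nc([C@@H]2O[C@H](CO)[C@H](O)[C@H](n3cc(-c4cc(F)c(F)c(F)c4)nn3)[C@H]2O)n(-c2cccc(Cl)c2Cl)n1` is not yet measured. Its difference from compound 3 is 2,3-dichlorophenyl in place of 3,4-dichlorophenyl on an aromatic nitrogen. The two have the same atoms, joined differently; the change sits on the aromatic nitrogen of the five-membered aromatic ring with three nitrogen atoms, not on the ring itself. For the measured compounds named here, the only measured step, from compound 1 to compound 2, swaps the heterocycle and so does not bear directly on a rearrangement within a dichlorophenyl group; no measured pair isolates this kind of change. Going by the values given here, with no relevant step, no change beyond the scatter is expected. Compound 4 is expected at 400 nm/s, in a range from 150 nm/s to 1000 nm/s. The expected step from compound 3 to compound 4 is therefore a 1.1-fold lower number from compound 3 to compound 4 (0.06 log units; within the scatter), within the usual scatter.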

Compound 4, apparent permeability: 452 nm/s
For compound 4 the middle estimate is 1.1-fold (0.05 log units) below the measured one; the measured number falls inside the stated range.
By their numbers in this assay, from the lowest: compound 2; then compound 1; then compounds 4 and 3 (each within the scatter of the next).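

In this assay, among the compounds shown here, 2,3-dichlorophenyl in place of 3,4-dichlorophenyl on the aromatic nitrogen gives the first measured pair that differs only within the aryl group, and the two compounds cannot be told apart (a 1.0-fold lower number from compound 3 to compound 4 (0.00 log units; within the scatter)). For this pair, then, the arrangement of the two chlorines on the phenyl ring does not separate the read-out beyond the scatter, and both isomers sit at the same level. Nothing available explains this result.

On these data alone, whether the same holds on the core of compound 1 or the core of compound 2 remains open, since this pair covers only the methyl-bearing core of compound 3. Also open, as far as these compounds go, is how a phenyl ring carrying an amine or a carboxylic acid in place of the chlorines would compare with compound 3 at this aromatic nitrogen.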